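This account rests on a few compounds, and the source may have more. Where it says the series, first, only, none or still open, it means among the compounds named here.

Of the compounds shown here, three have been measured in a functional assay on the whole organism (aorta) with Rattus norvegicus as the target; on this read-out lower numbers stand for smaller maximal responses and higher numbers for larger maximal responses. Compound 1 `CC1(C)C=C(n2ccccc2=O)c2cc(S(N)(=O)=O)ccc2O1` gives 77.5%, compound 2 `CC1(C)C=C(n2ccccc2=O)c2cc(S(=O)(=O)NCCO)ccc2O1` gives 95.5%, and compound 3 `CC1(C)C=C(n2ccccc2=O)c2cc(S(=O)(=O)NCc3ccccc3)ccc2O1` gives 71.1%. Compound 3 thus carries the lowest of the three numbers; it lies within the scatter of compound 1, but a number 24.4 percentage points lower from compound 2 to compound 3 (beyond the scatter) sets it apart from compound 2.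

Compound 4 `COc1ccc(NS(=O)(=O)c2ccc3c(c2)C(n2ccccc2=O)=CC(C)(C)O3)cc1` differs from compound 3 in one place: 4-methoxyphenyl in place of benzyl on a sulfonamide nitrogen. For the measured compounds named here, no measured step exchanges one aromatic group on the sulfonamide nitrogen for another, so the change has only indirect precedent. The step of a number 6.4 percentage points lower from compound 1 to compound 3 (within the scatter) shows that placing benzyl on that nitrogen left the maximal response essentially unchanged, whereas a number 24.4 percentage points lower from compound 2 to compound 3 (beyond the scatter) shows a modest fall when phenyl replaced hydroxymethyl. Since compound 4 keeps an aromatic group on the nitrogen and merely trades benzyl for 4-methoxyphenyl, no step beyond the scatter is expected in this assay. The expected step is a number 1.9 percentage points higher from compound 3 to compound 4 (within the scatter). Compound 4 is therefore estimated to give 73%, within a range of 58% to 88%.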

Compound 4, largest response reached (Emax), in percent of the reference or control that the assay uses: 77.9%
The estimate for compound 4 lay 4.9 percentage points below the measured number, within the range that was stated.
By their numbers in this assay, from the lowest: compounds 3, 1 and 4 (each within the scatter of the next); then compound 2.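

In this assay, the sulfonamide nitrogen tolerates a directly attached aromatic ring as well as the benzyl group: 4-methoxyphenyl in place of benzyl gives a number 6.8 percentage points higher from compound 3 to compound 4 (within the scatter) and 4-methoxyphenyl in place of hydrogen gives a number 0.4 percentage points higher from compound 1 to compound 4 (within the scatter) on the same nitrogen. Hydrogen, benzyl and 4-methoxyphenyl therefore form one group, and 2-hydroxyethyl alone stands apart from it, now also against 4-methoxyphenyl, with a number 17.6 percentage points lower from compound 2 to compound 4 (beyond the scatter) as the step. Nothing measured here bears on why the response divides in this way.

The compounds shown leave open whether an amine, a carboxylic acid or a longer chain ending in hydroxyl on that nitrogen would fall with compound 2 or with the other three. They also leave open whether plain phenyl there would match 4-methoxyphenyl.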